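Cytotoxicity limits across a dioxane-fused ketone series

A few compounds are considered here, and "the series" means these few. Any claim that something is new, unique, unknown or untested is made for them only; others in the source may bear on it.

Measured compounds:
- compound 1, `O=C(c1ccc2c(c1)OCCO2)C1CCN(Cc2coc(-c3ccccc3)n2)CC1` — > 150 ug/mL
- compound 2, `COc1ccc(-c2nc(CN3CCC(C(=O)c4ccc5c(c4)OCCO5)CC3)co2)cc1` — > 150 ug/mL
- compound 3, `COc1ccc(C(=O)C2CCN(Cc3coc(-c4ccc(F)cc4)n3)CC2)cc1OC` — > 150 ug/mL

In an ADME assay on HEK293 cells (Homo sapiens) for cytotoxicity, read by MTT assay, with a stated time of 36 h (on this read-out higher numbers stand for weaker inhibition and lower numbers for stronger inhibition), compound 1 gives only a limit, > 150 ug/mL. Compound 2 likewise gives only a limit in this assay, > 150 ug/mL. Compound 3 too reaches only a limit, > 150 ug/mL. The step that the two limits leave unreadable from compound 2 to compound 1 is therefore not readable, as the limit of > 150 ug/mL in this assay, at which 3 of the 3 values shown sit, shows; the change is hydrogen in place of methoxy on an aromatic carbon. How the core of compound 3 differs from that of compound 2 is not broken down here.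

Compound 4, `COc1ccc(C(=O)C2CCN(Cc3coc(-c4ccc(F)cc4)n3)CC2)cc1`, has not been measured. It carries the same kind of change as compound 1 does from compound 2, namely (hydrogen in place of methoxy on an aromatic carbon); the place differs, lying ortho to a methoxy group and meta to a large group rather than para to a large group. Because compound 3 sits at the limit of > 150 ug/mL in this assay, at which 3 of the 3 values shown sit, the step that the limit leaves unreadable from compound 3 to compound 4 is expected to remain unreadable. Compound 4 is estimated at 200 ug/mL, between 120 ug/mL and 400 ug/mL.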

Compound 4, half-maximal inhibitory concentration: > 150 ug/mL
Compound 4 gave a limit, no number; the forecaster's own chance of this, stated with the estimate: 85%; the middle value lies beyond the limit too.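

In this assay no step can be read from compound 3 to compound 4, as each gives only a limit: the limit of > 150 ug/mL in this assay, at which 4 of the 4 values shown sit. The compounds shown leave open where any of them would register in this assay and whether the methoxy group changes that.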